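A few compounds are considered here, and "the series" means these few. Any claim that something is new, unique, unknown or untested is made for them only; others in the source may bear on it.

Measured in a functional assay on MCF7 cells (Homo sapiens) for inhibition, read by CCK-8 assay, with a stated time of 48 h; on this read-out higher numbers stand for weaker inhibition of growth and lower numbers for stronger inhibition of growth:
- compound 1 `Cc1ccccc1Nc1nc(Nc2ccc(N3CCN(C)CC3)cn2)ncc1Cl`: 5210 nM
- compound 2 `CN1CCN(c2ccc(Nc3ncc(Cl)c(NCc4ccccc4)n3)nc2)CC1`: 17300 nM

Of these two, compound 2 has the higher number, at 17300 nM, and so shows the weaker inhibition of growth. The next step leads to compound 3 `Cc1ccc(CNc2nc(Nc3ccc(N4CCN(C)CC4)cn3)ncc2Cl)cc1`, which is still unmeasured. The change is methyl in place of hydrogen on an aromatic carbon, turning benzyl into 4-methylbenzyl. For the measured compounds named here, only one measured step bears on it, a 3.3-fold higher number from compound 1 to compound 2 (0.52 log units; beyond the scatter), with benzyl in place of 2-methylphenyl on a nitrogen on an aromatic ring. That step is modest, and it does not measure this methyl on a benzyl group. No step beyond the scatter is therefore expected in this assay, and no direction can be firmly expected. The estimated step is a 1.2-fold lower number from compound 2 to compound 3 (0.09 log units; within the scatter). For compound 3 the expected value is 14000 nM, with an estimated range of 6500 nM to 30000 nM.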

Compound 3, concentration for 50% growth inhibition: 38100 nM
The estimate for compound 3 lay 2.7-fold (0.43 log units) below the measured number, and the stated range ends below it.
By their numbers in this assay, from the lowest: compound 1; then compound 2; then compound 3.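

Turning benzyl into 4-methylbenzyl gives a 2.2-fold higher number from compound 2 to compound 3 (0.34 log units; beyond the scatter) in this assay, so a single methyl on this ring carbon, para to a large group, moves the number beyond the scatter towards weaker inhibition of growth. Replacing 2-methylphenyl with 4-methylbenzyl gives a 7.3-fold higher number from compound 1 to compound 3 (0.86 log units; beyond the scatter), a larger step than either of the other two, and compound 1 keeps the lowest number of the three. The data shown offer no explanation for the effect of this methyl.

The compounds shown leave open whether this shift is specific to methyl, since no chlorine, methoxy or hydroxyl group appears on this ring carbon. They also leave open how an ethyl or a longer chain would read there.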